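Notes on the step from compound 2 to compound 3

The compounds below may be only part of what the source reports. "The series", "measured", "known", "first", "only" and "open" are said of these compounds alone.

Going by the values given here, in a functional assay on HeLa cells (Homo sapiens) for antiproliferative activity, read by MTT assay, with a stated time of 72 h (on this read-out lower numbers stand for stronger inhibition and higher numbers for weaker inhibition), compound 1 `Nc1nc(N)c2cc(CSC(=S)N3CCN(C4CCCCC4)CC3)ccc2n1` gives 5960 nM and compound 2 `Nc1nc(N)c2cc(CSC(=S)N3CCN(c4ccc(Cl)c(Cl)c4)CC3)ccc2n1` gives 3060 nM, so compound 2 stands within the scatter of the only other measured value. The unmeasured compound 3 `Nc1nc(N)c2cc(CSC(=S)N3CCN(c4ccccc4F)CC3)ccc2n1` carries 2-fluorophenyl in place of 3,4-dichlorophenyl on an amine nitrogen in a ring. Among the compounds with values here, one measured step bears on this place: a 1.9-fold lower number from compound 1 to compound 2 (0.29 log units; within the scatter), with 3,4-dichlorophenyl in place of cyclohexyl, and it stays within the scatter. Within the data shown here, no measured compound carries 2-fluorophenyl, so this single step is thin evidence. On these data alone, no change beyond the scatter is expected in this assay, and the direction remains open. The expected step is a 1.1-fold higher number from compound 2 to compound 3 (0.06 log units; within the scatter). For compound 3 the estimated value is 3500 nM, with an expected range of 1400 nM to 8000 nM.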

Compound 3, half-maximal inhibitory concentration: 6660 nM
For compound 3 the middle estimate is 1.9-fold (0.28 log units) below the measured one, and the stated range covers the measured number.
By their numbers in this assay, from the lowest: compounds 2, 1 and 3 (each within the scatter of the next, the first and the last beyond it).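

In this assay the group on the amine nitrogen in the ring now gives a step beyond the scatter, which the cyclohexyl to 3,4-dichlorophenyl change did not: a 2.2-fold higher number from compound 2 to compound 3 (0.34 log units; beyond the scatter) is modest and comes with 2-fluorophenyl in place of 3,4-dichlorophenyl. Going by these compounds alone, by contrast, a 1.1-fold higher number from compound 1 to compound 3 (0.05 log units; within the scatter) stays within the scatter, so 2-fluorophenyl and cyclohexyl are not told apart at this place, and only the pair of two aryl groups separates. Nothing measured here accounts for that separation.

Since 3,4-dichlorophenyl and 2-fluorophenyl differ in both the halogen and its place on the ring, these compounds cannot show which of the two goes with the step. Plain phenyl, 2-chlorophenyl or 3,4-difluorophenyl at this nitrogen would bear on that question.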